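Compound 3 and the step to compound 4

This account rests on a few compounds, and the source may have more. Where it says the series, first, only, none or still open, it means among the compounds named here.

Measured in an ADME assay on microsomes from liver (Mus musculus) for metabolic stability, using NADPH, with a stated time of 10 min; on this read-out higher numbers stand for a more stable compound and lower numbers for a less stable compound:
- compound 1 `NCCCCN(C[C@H]1Cc2cccnc2CN1)[C@H]1CCCc2cccnc21`: 69%
- compound 2 `NCCCCN(C[C@H]1Cc2nccnc2CN1)[C@H]1CCCc2cccnc21`: 77%
- compound 3 `NC/C=C/CN(C[C@H]1Cc2ncccc2CN1)[C@H]1CCCc2cccnc21`: 37%

Among these three, compound 3 stands lowest at 37%, and the gap to each of the other two lies beyond the scatter.

Compound 4 `CCN(CC)CCCCN(C[C@H]1Cc2ncccc2CN1)[C@H]1CCCc2cccnc21` keeps the core of compound 3 and changes in one place: 3-(diethylamino)propyl in place of 3-aminoprop-1-en-1-yl on a saturated chain carbon bound to an amine nitrogen. In words, 3-(diethylamino)propyl stands in place of 3-aminoprop-1-en-1-yl on a saturated chain carbon bound to an amine nitrogen.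

Among the measured compounds shown here, no two measured compounds differ in only one place, so the data give no direct measure of such a step. The expectation rests on indirect evidence. Compound 1 gives 69% and compound 2 gives 77% in this assay, and both carry a saturated chain, as compound 4 does, although on other cores and without the diethylamino end. A modest rise is therefore expected, with a real chance that it stays within the scatter. The expected change is a number 10 percentage points higher from compound 3 to compound 4 (within the scatter). Compound 4 is estimated at 47%, with an expected range from 24% to 70%.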

Compound 4, percent of the compound remaining: 1%
Compound 4: middle estimate off by 46 percentage points, on the high side; the whole stated range lies above it.
By their numbers in this assay, from the lowest: compound 4; then compound 3; then compounds 1 and 2 (each within the scatter of the next).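

Among the compounds shown here, on the core of compound 3, the place on a saturated chain carbon bound to an amine nitrogen proves to matter greatly in this assay: 3-(diethylamino)propyl in place of 3-aminoprop-1-en-1-yl gives a number 36 percentage points lower from compound 3 to compound 4 (beyond the scatter), the first step in the set that changes only one place. A saturated chain alone therefore does not secure a high number in this assay, since compound 4 carries such a chain and gives 1%, which leaves very little of the compound after the stated time. Nothing available here bears on why the number falls so far, and the step itself gives no cause.

For the compounds shown here, the single step changes several things together, as the double bond leaves, the chain end gains its diethylamino group and the number of heavy atoms rises, so it remains open which of these carries the loss. Also open, from the compounds shown here alone, is how this core would fare with a saturated butyl chain ending in a primary amine, or with a dimethylamino or pyrrolidine group at the chain end.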